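Chloro for Methyl Beside a Changed Charged Tail

A few compounds are considered here, and "the series" means these few. Any claim that something is new, unique, unknown or untested is made for them only; others in the source may bear on it.

Measured so far:
compound 1, `Cc1cc(-n2cc(C(=O)Nc3cc(F)cc(F)c3)c(=O)c3ccc(N(C)C)nc32)ccc1OCCCCCCC[N+]12CCN(CC1)CC2`: 20.8%
compound 2, `CN(C)c1ccc2c(=O)c(C(=O)Nc3cc(F)cc(F)c3)cn(-c3ccc(OCCCCCCC[N+]45CCN(CC4)CC5)c(Cl)c3)c2n1`: 20.5%
compound 3, `CC[N+]1(CCCCCCCOc2ccc(-n3cc(C(=O)Nc4cc(F)cc(F)c4)c(=O)c4ccc(N(C)C)nc43)cc2C)CCCC1`: 82.5%

All three were tested in an assay on LX2 cells for inhibition of COL1A1 promoter (Homo sapiens), read by a luciferase reporter, with a stated time of 24 h, tested at 50 uM; on this read-out lower numbers stand for a weaker effect and higher numbers for a stronger effect at the one concentration tested. Compound 1 and compound 2 differ by one exchange, (chloro in place of methyl on an aromatic carbon), and this gave a number 0.3 percentage points lower from compound 1 to compound 2 (within the scatter), so the two values show no ordering between them. Compound 3 differs from compound 1 in its core: a group of 7 heavy atoms (6 carbon, 1 nitrogen; one five-membered non-aromatic ring with 1 hetero atom) in place of a group of 8 heavy atoms (6 carbon, 2 nitrogen; 2 six-membered non-aromatic rings with 2 hetero atoms each), on a saturated chain carbon, seven bonds along the chain from an oxygen on an aromatic ring. That exchange gave a number 61.7 percentage points higher from compound 1 to compound 3 (beyond the scatter), and compound 3 stands highest of the three measured compounds, beyond the scatter from both others.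

Compound 4 `CC[N+]1(CCCCCCCOc2ccc(-n3cc(C(=O)Nc4cc(F)cc(F)c4)c(=O)c4ccc(N(C)C)nc43)cc2Cl)CCCC1` has not been measured yet. It stands to compound 3 as compound 2 stands to compound 1: the change is chloro in place of methyl on an aromatic carbon, and its place is described in exactly the same words as before, so it is the same change on the other core. The expectation rests on the earlier exchange, which moved the read-out by only a number 0.3 percentage points lower from compound 1 to compound 2 (within the scatter), and on compound 3, which gives 82.5%. Compound 4 is therefore expected to give about 80%, with a likely range from 62% to 94%. The expected step is a number 2.5 percentage points lower from compound 3 to compound 4 (within the scatter), a small movement within the usual scatter.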

Compound 4, a percentage reported as inhibition, at one concentration (the size of the read-out at that concentration, not a potency): 23.5%
Compound 4: the middle estimate sits 56.5 percentage points above what was measured; the whole stated range lies above it.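

Chloro in place of methyl gave a number 59 percentage points lower from compound 3 to compound 4 (beyond the scatter) in this assay, so the near-silent exchange on the core of compound 1 did not carry over to the core of compound 3: the same change on two cores in this assay, a number 0.3 percentage points lower (within the scatter) from compound 1 to compound 2 and a number 59 percentage points lower (beyond the scatter) from compound 3 to compound 4, 58.7 percentage points apart, beyond the scatter of two such steps

Read the other way, the exchange of the charged tail gave a number 3 percentage points higher from compound 2 to compound 4 (within the scatter), so the large gain seen with methyl did not appear with chloro: the same change on two cores in this assay, a number 61.7 percentage points higher (beyond the scatter) from compound 1 to compound 3 and a number 3 percentage points higher (within the scatter) from compound 2 to compound 4, 58.7 percentage points apart, beyond the scatter of two such steps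

This shows that, across these four compounds, the effect of each change depends on the other and cannot be transferred as a fixed increment, but it does not show why, and it reaches no further than the read-out at the one concentration tested.

The compounds shown leave open whether the high read-out of compound 3 is particular to methyl or also holds with fluoro, ethyl or methoxy in that place. They also leave open how a longer chain or an uncharged tertiary amine at the end of the chain would behave with methyl or chloro.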